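A Piperidine Swap on Compound 2's Chain

The source may hold more compounds than are shown below. What is called first, only, known or untested is meant among the compounds shown, and "the series" means these compounds.

Among the compounds with values here, in a physicochemical assay for permeability, using PAMPA (on this read-out lower numbers stand for lower permeability and higher numbers for higher permeability), compound 2 `Cc1ccccc1-c1nc(CN2CCC(C(=O)NCCCN3CCCCC3)CC2)c(C)o1` gives 34.5 10^-6 cm/s, the lowest of the three numbers measured so far. Compound 3 `Cc1oc(-c2c(F)cccc2F)nc1CN1CCC(C(=O)NCCCN2C[C@H](C)C[C@H](C)C2)CC1` stands higher at 82.4 10^-6 cm/s, and compound 1 `Cc1oc(-c2c(C)c(C)c(C)c(C)c2C)nc1CN1CCC(C(=O)NCCCN2C[C@H](C)C[C@H](C)C2)CC1` stands highest at 455 10^-6 cm/s.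

The next compound to be measured is compound 4 `Cc1ccccc1-c1nc(CN2CCC(C(=O)NCCN3C[C@H](C)C[C@H](C)C3)CC2)c(C)o1`. It differs from compound 2 by one change: 3,5-dimethylpiperidin-1-yl in place of (piperidin-1-yl)methyl on a saturated chain carbon, two bonds along the chain from an amide-type nitrogen. The change sits on a saturated chain carbon, two bonds along the chain from an amide-type nitrogen. Cut one bond further out, it reads 3-(piperidin-1-yl)propyl to 2-(3,5-dimethylpiperidin-1-yl)ethyl.

Within the data shown here, no measured step touches this place. The only one available, a 5.5-fold lower number from compound 1 to compound 3 (0.74 log units; beyond the scatter), is a modest step made on an aromatic carbon elsewhere in the molecule. It shows how far this assay can move within this small set, but it gives no direction for the present change. Compounds 1 and 3 both carry 3,5-dimethylpiperidin-1-yl and both exceed compound 2, which hints weakly at a rise, yet neither has the shorter chain.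

The expected step is small and upward, probably not beyond the scatter: a 1.4-fold higher number from compound 2 to compound 4 (0.14 log units; within the scatter). For compound 4 the estimated value is 48 10^-6 cm/s, with an expected range from 17 10^-6 cm/s to 135 10^-6 cm/s.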

Compound 4, apparent permeability: 712 10^-6 cm/s
Estimate against measurement, compound 4: 15-fold (1.17 log units) below, outside the stated range (above it).
By their numbers in this assay, from the lowest: compound 2; then compound 3; then compounds 1 and 4 (each within the scatter of the next).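

In this assay the saturated chain carbon, two bonds along the chain from an amide-type nitrogen, turns out to be a place where one change moves the number a long way: 2-(3,5-dimethylpiperidin-1-yl)ethyl in place of 3-(piperidin-1-yl)propyl gives a 21-fold higher number from compound 2 to compound 4 (1.31 log units; beyond the scatter) and counts as a large step. Within the data shown here, the only earlier step, a 5.5-fold lower number from compound 1 to compound 3 (0.74 log units; beyond the scatter) on an aromatic carbon, was modest and pointed downward, so the chain position has now produced the larger move of the two, and an upward one. Nothing among the data shown explains why this step is so large.

The change alters the chain and the ring at once, shortening the chain while adding two methyl groups and two defined stereocentres, so the compounds shown cannot divide the step between those parts. Going by these compounds, what a 2-(piperidin-1-yl)ethyl chain or a 3-(3,5-dimethylpiperidin-1-yl)propyl chain would give on the core of compound 2 remains open, and so does the reading for a morpholine ring at the end of the chain.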